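A few compounds are considered here, and "the series" means these few. Any claim that something is new, unique, unknown or untested is made for them only; others in the source may bear on it.

Of the compounds shown here, three have been measured in a functional assay on NCI-H460 cells (Homo sapiens) for inhibition, read by MTT assay, with a stated time of 24 h, tested at 100 ug/mL; a higher number here means more inhibition of growth at the concentration tested, a lower number less inhibition of growth: compound 1 `CC(=O)SCCC(CCCCC(=O)O)SC(C)=O` gives 11%, compound 2 `O=C(O)CCCCC(CCSC(=O)c1ccccc1)SC(=O)c1ccccc1` gives 72.8%, and compound 3 `CC(=O)SCCC(CCCCC(=O)Nc1ccccc1)SC(C)=O` gives 44.8%. Compound 4 `O=C(CCCCC(CCSC(=O)c1ccccc1)SC(=O)c1ccccc1)Nc1ccccc1` remains to be measured.

Compound 3 arises from compound 1 by a single change, (anilino in place of hydroxy on a carbonyl carbon), and this change raised growth inhibition strongly: a number 33.8 percentage points higher from compound 1 to compound 3 (beyond the scatter). Compound 4 arises from compound 2 by the same change, (anilino in place of hydroxy on a carbonyl carbon), at the same kind of place. How the core of compound 1 and the core of compound 2 differ is not broken down here; their values alone show that compound 2 stands well above compound 1. Because compound 2 already reaches 72.8%, little room is left to rise, so the expected step of a number 13.2 percentage points higher from compound 2 to compound 4 (beyond the scatter) is smaller than the earlier one. Compound 4 is estimated at 86%, between 66% and 98%.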

Compound 4, percent growth inhibition at one concentration: "not active" (no number reported)
No number was reported for compound 4, and the estimate cannot be compared.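

Compound 4 carries only the remark "not active" in this assay and no number, so no step from compound 2 to compound 4 can be read, and nothing available explains that remark. Still open, from the compounds shown here alone, is how far anilino in place of hydroxy changes growth inhibition on the core of compound 2.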